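The source may hold more compounds than are shown below. What is called first, only, known or untested is meant among the compounds shown, and "the series" means these compounds.

Measured so far:
Compound 1 `CN(C)Cc1ccccc1-c1ccc(N2CCc3c(C(F)(F)F)nn(-c4ccc5onc(N)c5c4)c3C2=O)c(F)c1`: 6.4 h
Compound 2 `CNCc1ccccc1-c1ccc(N2CCc3c(C(F)(F)F)nn(-c4ccc5onc(N)c5c4)c3C2=O)cc1`: 7.4 h

Both compounds were tested in an in vivo ADME assay on the whole organism for metabolic stability, with Canis familiaris (Canis lupus familiaris) as the target; on this read-out lower numbers stand for a shorter-lived compound and higher numbers for a longer-lived compound. Compound 2, at 7.4 h, lies within the scatter of compound 1, so the two cannot be ranked against each other. Compound 3 `CN(C)Cc1ccccc1-c1ccc(N2CCc3c(C(F)(F)F)nn(-c4ccc5onc(N)c5c4)c3C2=O)cc1` has not yet been measured. Its difference from compound 2 is methyl in place of hydrogen on an amine nitrogen, which turns (methylamino)methyl into (dimethylamino)methyl. Among the measured compounds shown here, no measured pair shows this change alone, so its size can only be expected. Compound 1 also carries 2-((dimethylamino)methyl)phenyl and gives 6.4 h, so no shift beyond the scatter is expected in this assay. The expected change is small, a 1.1-fold lower number from compound 2 to compound 3 (0.04 log units; within the scatter). Compound 3 is estimated at 6.8 h, with an expected range of 3.5 h to 12 h.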

Compound 3, half-life: 3.8 h
Compound 3: the middle estimate sits 1.8-fold (0.25 log units) above what was measured; the measured number falls inside the stated range.
By their numbers in this assay, from the lowest: compounds 3, 1 and 2 (each within the scatter of the next).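

Methyl in place of hydrogen on the amine nitrogen can now be read alone in this assay as a 1.9-fold lower number from compound 2 to compound 3 (0.29 log units; within the scatter) and so, on this evidence, the change from (methylamino)methyl to (dimethylamino)methyl gives no shift that can be told from the scatter. Hydrogen in place of fluoro on an aromatic carbon can also be read alone, as a 1.7-fold lower number from compound 1 to compound 3 (0.23 log units; within the scatter) and thus this exchange likewise cannot be told from the scatter, with neither step showing a firm direction. Nothing available explains these values.

The compounds shown leave open whether a larger group on the amine nitrogen, such as ethyl, or a ring amine such as pyrrolidine would change the half-life beyond the scatter. They also leave open what chloro or methoxy would do on that aromatic carbon.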